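Swapping a chloro-substituted ring for a pyridyl ring

The source may hold more compounds than are shown below. What is called first, only, known or untested is meant among the compounds shown, and "the series" means these compounds.

Compound 2 `O=C(CCc1ccc(-c2cccc(Cl)c2)cc1)N1CCCC1` gives 25400 nM in an assay on HEK293 cells for inhibition of N-acylethanolamine-hydrolyzing acid amidase (Rattus norvegicus), read by LC-MS, with a stated time of 30 min (on this read-out lower numbers stand for stronger inhibition and higher numbers for weaker inhibition), the higher of the two numbers recorded, while compound 1 `O=C(CCc1ccc(-c2cccc(F)c2)cc1)N1CCCC1` gives 1800 nM in this assay. Among the compounds with values here, the one measured step, a 14-fold higher number from compound 1 to compound 2 (1.15 log units; beyond the scatter), shows that exchanging the halogen on the pendant ring moves the read-out far beyond the scatter. Compound 3 `O=C(CCc1ccc(-c2cccnc2)cc1)N1CCCC1` differs from compound 2 by pyridin-3-yl in place of 3-chlorophenyl on an aromatic carbon. Within the data shown here, no measured step covers this replacement directly; the only related information is that compound 2, which carries the chloro group, sits at the weak end, so removing that group and its ring for the pyridyl ring is expected to bring the number down rather than up, though by an uncertain amount. For compound 3 the estimate in this assay is 5000 nM, within 900 nM to 25000 nM. This corresponds to an expected step of a 5.1-fold lower number from compound 2 to compound 3 (0.71 log units; beyond the scatter).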

Compound 3, half-maximal inhibitory concentration: > 100000 nM
Compound 3: a limit, no number (the forecaster's own chance of this, stated with the estimate: 5%); at least 20-fold (1.30 log units) between middle value and limit.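

Exchanging the whole pendant ring, and not only its halogen, gives an at least 3.9-fold higher number from compound 2 to compound 3 (0.59 log units; beyond the scatter), and against the fluoro analogue it gives an at least 55-fold higher number from compound 1 to compound 3 (1.74 log units; beyond the scatter). The earlier pair showed only that the read-out responds to which halogen the ring carries, whereas these steps show that pyridin-3-yl on this aromatic carbon reads weaker than either halogen-bearing ring, so compound 2 no longer marks the weak end of the series. The entry for compound 3 is a limit of the assay and not a number: the limit of > 100000 nM in this assay, at which 1 of the 3 values shown sits.

Going by these compounds, how far compound 3 lies past that limit stays open, so both steps have a lower bound only. Also open, on these data alone, is whether the ring nitrogen or the missing halogen accounts for the change, which a plain phenyl ring or a fluoro-substituted pyridin-3-yl ring would help to separate.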